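This account rests on a few compounds, and the source may have more. Where it says the series, first, only, none or still open, it means among the compounds named here.

Compound 1 `CCCCCC(C#CC(=O)OC)O/C=C/C(=O)OC`: 1700 nM
Compound 2 `CCCCCCC(C#CC(=O)OC)O/C=C/C(=O)OC`: 3300 nM
Compound 3 `CCCC(C#CC(=O)OC)O/C=C/C(=O)OC`: 320 nM

These values come from a functional assay on SW1573 cells (Homo sapiens) for antiproliferative activity, read by sulforhodamine B assay, with a stated time of 48 h; on this read-out higher numbers stand for weaker inhibition of growth and lower numbers for stronger inhibition of growth. Compound 3 has the lowest number of the three, and it also has the shortest chain. Compound 4 `COC(=O)C#CC(C[C@@H](C)CCC=C(C)C)O/C=C/C(=O)OC` differs from compound 3 at one place: 4-methylpent-3-en-1-yl in place of hydrogen on a saturated chain carbon bound to two saturated chain carbons. Within the data shown here, two measured steps bear on this change, a 5.3-fold lower number from compound 1 to compound 3 (0.73 log units; beyond the scatter) and a 10-fold lower number from compound 2 to compound 3 (1.01 log units; beyond the scatter), both of which shorten the chain. A third, a 1.9-fold higher number from compound 1 to compound 2 (0.29 log units; within the scatter), lies within the scatter. None of these steps involves a branch or a double bond, so the comparison is only approximate. In this assay a large step towards a higher number is therefore expected, and the estimated step is a 7.8-fold higher number from compound 3 to compound 4 (0.89 log units; beyond the scatter). For compound 4 the estimated value is 2500 nM, with an expected range of 800 nM to 8000 nM.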

Compound 4, concentration for 50% growth inhibition: 2200 nM
Estimate against measurement, compound 4: 1.1-fold (0.06 log units) above; the range from low to high includes it.
By their numbers in this assay, from the lowest: compound 3; then compounds 1, 4 and 2 (each within the scatter of the next).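

In this assay, adding 4-methylpent-3-en-1-yl on a saturated chain carbon bound to two saturated chain carbons gives a 6.9-fold higher number from compound 3 to compound 4 (0.84 log units; beyond the scatter). Compound 4 is the only compound shown with a branch and a double bond in its chain, and it shows that the number also rises with this kind of group, not only with unbranched chains. Nothing shown explains this rise.

As far as these compounds go, it remains open whether the double bond contributes to this step, as a saturated 4-methylpentyl group would test. From the compounds shown here alone, a phenyl ring or a hydroxyl group at this place also remains open.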